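Methyl for hydrogen on a glycine-like linker of a furoxan hybrid

The compounds below may be only part of what the source reports. "The series", "measured", "known", "first", "only" and "open" are said of these compounds alone.

Compound 1 `CC(C)=CCC/C(C)=C/CC/C(C)=C/CSc1ccccc1C(=O)NCC(=O)OCC#CCOc1no[n+]([O-])c1S(=O)(=O)c1ccccc1` was tested in a functional assay on MCF7 cells (Homo sapiens) for cytotoxicity, read by MTT assay, with a stated time of 48 h (a lower number here means a stronger inhibitor, a higher number a weaker inhibitor), where compound 1 gives 6910 nM. Its two companions sit close by: compound 2 `CC(C)=CCC/C(C)=C/CC/C(C)=C/CSc1ccccc1C(=O)N1CCC[C@H]1C(=O)OC(C)CCOc1no[n+]([O-])c1S(=O)(=O)c1ccccc1` gives 6500 nM, and compound 3 `CC(C)=CCC/C(C)=C/CC/C(C)=C/CSc1ccccc1C(=O)N[C@@H](C)C(=O)OC(C)CCOc1no[n+]([O-])c1S(=O)(=O)c1ccccc1` gives 11100 nM; none of these three numbers is apart from another beyond the usual scatter. Compound 4 `CC(C)=CCC/C(C)=C/CC/C(C)=C/CSc1ccccc1C(=O)N[C@@H](C)C(=O)OCC#CCOc1no[n+]([O-])c1S(=O)(=O)c1ccccc1` has not been measured. It differs from compound 1 by methyl in place of hydrogen on a saturated chain carbon bound to an amide-type nitrogen and a carbonyl carbon. For the measured compounds named here, no step between measured compounds isolates this change, and the closest hint, the values of compound 1 and compound 3, shows nothing beyond the scatter. The expected step of a 1.2-fold higher number from compound 1 to compound 4 (0.09 log units; within the scatter) is therefore none beyond the scatter, if anything a slightly higher number. Compound 4 is estimated at 8500 nM, with a range from 3500 nM to 20000 nM.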

Compound 4, half-maximal inhibitory concentration: 5030 nM
The estimate for compound 4 lay 1.7-fold (0.23 log units) above the measured number, within the range that was stated.
By their numbers in this assay, from the lowest: compounds 4, 2, 1 and 3 (each within the scatter of the next, the first and the last beyond it).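

Methyl in place of hydrogen on a saturated chain carbon bound to an amide-type nitrogen and a carbonyl carbon now has a step of its own in this assay (a 1.4-fold lower number from compound 1 to compound 4 (0.14 log units; within the scatter)). For the compounds shown here, this position therefore accepts the methyl without a shift beyond the scatter, which the earlier compounds could only hint at. Nothing available explains the result. Open, going by these compounds, is whether a longer chain, a benzyl group or a carboxylic acid on this carbon would leave the number within the scatter, and whether the opposite configuration there would do the same.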